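A few compounds are considered here, and "the series" means these few. Any claim that something is new, unique, unknown or untested is made for them only; others in the source may bear on it.

Compound 1 `Nc1nc(Cl)c(-c2nc3ccccc3o2)c(N[C@@H]2C[C@H](CO)[C@@H](O)[C@H]2O)n1` and compound 2 `Cc1nc(NC(C)(C)C)nc(N[C@@H]2C[C@H](CO)[C@@H](O)[C@H]2O)c1-c1nc2ccccc2s1` have both been tested in an ADME assay on cells (Homo sapiens) for cytotoxicity, read by polymerase chain reaction, with a stated time of 3 days; on this read-out lower numbers stand for higher toxicity in this test and higher numbers for lower toxicity in this test. In this assay compound 1 gives 12000 nM, and compound 2 gives 12000 nM. Compound 2 thus stands level with compound 1 at the digits recorded, a difference that lies within the usual scatter of repeated measurements, even though the two compounds share only part of their structure. Compound 3 `Cc1nc(NCCNS(C)(=O)=O)nc(N[C@@H]2C[C@H](CO)[C@@H](O)[C@H]2O)c1-c1nc2ccccc2s1` has not yet been measured. It differs from compound 2 in one place: 2-(methanesulfonamido)ethyl in place of tert-butyl on a nitrogen on an aromatic ring. Within the data shown here, no measured pair in this set shows what a change of this kind does in this assay, and the two compounds measured so far sit at the same value despite their differences. The expected step is therefore small, with no direction that goes beyond the scatter: no change at the digits printed from compound 2 to compound 3 (within the scatter). Compound 3 is estimated to give 12000 nM in this assay, with a range from 5000 nM to 30000 nM.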

Compound 3, half-maximal cytotoxic concentration: > 25000 nM
Compound 3: a limit, no number; the forecaster's own chance of this, stated with the estimate: 30%; middle value at least 2.0-fold (0.31 log units) away from the limit.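

In this assay compound 3 gives > 25000 nM, which is a limit of the assay and not a number. Among these compounds, replacing tert-butyl with 2-(methanesulfonamido)ethyl on a nitrogen on an aromatic ring gives an at least 2.0-fold higher number from compound 2 to compound 3 (0.31 log units; beyond the scatter), the first one-place step in this set, so it shows that the number in this test responds to the group at this position and moves towards lower toxicity. The step has a lower bound but no fixed size, and the reading for compound 3 marks the top of what this test reports here: the limit of > 25000 nM in this assay, at which 1 of the 3 values shown sits.

The compounds shown leave open which part of the new chain goes with this step. A plain ethyl chain, a 2-hydroxyethyl chain, an amine or a carboxylic acid on the same nitrogen could separate the methanesulfonamide from the chain that carries it.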